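Working notes: chloro in place of amino

The source may report more compounds than this note shows. Statements on the series, on what has been measured and on what is new or still open speak of the compounds shown alone.

Measured in a functional assay on U-937/GTB cells (Homo sapiens) for cytotoxicity; a lower number here means a stronger inhibitor, a higher number a weaker inhibitor:
- compound 1 `CC(C)=CCC/C(C)=C/CC/C(C)=C/CC/C(C)=C/C[n+]1cn(C)c2nc[nH]/c(=N\OCc3ccccc3)c21`: 6790 nM
- compound 2 `CO/N=c1\[nH]cnc2c1[n+](C/C=C(\C)CCCC(C)CCCC(C)CCCC(C)C)cn2C`: 5400 nM
- compound 3 `CC(C)=CCC/C(C)=C/CC/C(C)=C/CC/C(C)=C/Cn1cnc2ncnc(N)c21`: 3600 nM

In this assay, compound 3 gives 3600 nM, which lies within the scatter of the values for both compound 1 and compound 2. The three measurements therefore set no order among these compounds.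

The next compound is compound 4 `CC(C)=CCC/C(C)=C/CC/C(C)=C/CC/C(C)=C/Cn1cnc2ncnc(Cl)c21`, with chloro in place of amino on an aromatic carbon. Among the compounds with values here, no measured pair isolates a single change, so the data hold no direct precedent for this exchange. No step beyond the scatter is expected in this assay, and no direction is favoured. This expectation rests only on the close grouping of the three measured values, with compound 3 at 3600 nM as the starting point. The estimated change is a 1.1-fold higher number from compound 3 to compound 4 (0.05 log units; within the scatter). For compound 4, the estimated value is 4000 nM, with an expected range of 1500 nM to 10000 nM.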

Compound 4, half-maximal inhibitory concentration: 5070 nM
Compound 4: middle estimate off by 1.3-fold (0.10 log units), on the low side, within the range that was stated.
By their numbers in this assay, from the lowest: compounds 3, 4, 2 and 1 (each within the scatter of the next).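

In this assay the series now has its first pair differing in one place: chloro in place of amino on an aromatic carbon gives a step (a 1.4-fold higher number from compound 3 to compound 4 (0.15 log units; within the scatter)) that cannot be told from repeat scatter. The hydrogen-bond donor and acceptor counted on the amino group leave with it and chloro brings neither, yet the read-out does not separate the two compounds, so with this chain the amino group is not shown to be needed at this position. No evidence is available that would explain this outcome.

As far as these compounds go, whether a methoxy or a dimethylamino group on this carbon would give a step beyond the scatter stays open. Also open, from the compounds shown here alone, is whether the same exchange would read alike with the chain of compound 2.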